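Extending the chain of compound 2: outlook for compound 3

The source may hold more compounds than are shown below. What is called first, only, known or untested is meant among the compounds shown, and "the series" means these compounds.

Measured in a functional assay on MDA-MB-231 cells (Homo sapiens) for antiproliferative activity, read by MTT assay, with a stated time of 48 h; on this read-out higher numbers stand for weaker inhibition and lower numbers for stronger inhibition:
compound 1 `COc1ccc(N(C)c2ccnc(Cl)n2)cc1O`: 833 nM
compound 2 `COc1ccc(N(C)c2ccnc(Cl)n2)cc1OCC[Se]C#N`: 2750 nM

Of the two measured compounds, compound 2 holds the higher number, at 2750 nM. Among the compounds with values here, the only measured step is a 3.3-fold higher number from compound 1 to compound 2 (0.52 log units; beyond the scatter), a modest one beyond the scatter, and it replaces a hydrogen atom on an oxygen on an aromatic ring. Compound 3 `COc1ccc(N(C)c2ccnc(Cl)n2)cc1OCCCC[Se]C#N` differs from compound 2 as follows: a group of 5 heavy atoms (3 carbon, 1 nitrogen, 1 selenium; no ring) in place of a group of 3 heavy atoms (1 carbon, 1 nitrogen, 1 selenium; no ring), on a saturated chain carbon, two bonds along the chain from an oxygen on an aromatic ring. The change lies on a saturated chain carbon, two bonds along the chain from an oxygen on an aromatic ring. Within the data shown here, no measured step covers this kind of change, so a 3.3-fold higher number from compound 1 to compound 2 (0.52 log units; beyond the scatter) is only a loose guide to size and gives no direction. In this assay, no step beyond the scatter is expected, and the estimated step is a 1.1-fold lower number from compound 2 to compound 3 (0.04 log units; within the scatter). The expected value for compound 3 is 2500 nM, with an estimated range of 900 nM to 6500 nM.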

Compound 3, half-maximal inhibitory concentration: > 10000 nM
Compound 3 ended at the assay's limit; the forecaster's own chance of this, stated with the estimate: 3%; at least 4.0-fold (0.60 log units) between middle value and limit.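

In this assay compound 3 gives > 10000 nM, which is a limit of the assay and not a number. The change on a saturated chain carbon, two bonds along the chain from an oxygen on an aromatic ring, gives an at least 3.6-fold higher number from compound 2 to compound 3 (0.56 log units; beyond the scatter), so chain length is not neutral at this place, and across the three compounds the number rises in one direction, with an at least 12-fold higher number from compound 1 to compound 3 (1.07 log units; beyond the scatter). Both steps are lower bounds and not sizes, because compound 3 has no number of its own: the limit of > 10000 nM in this assay, at which 1 of the 3 values shown sits.

As far as these compounds go, whether a longer chain would stay at this limit remains open. Also open, from the compounds shown here alone, is whether the rise follows the chain alone or also needs the selenium and nitrile end, which an amine or a carboxylic acid on the same chain would help to separate.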